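Repeating a Chlorine Addition on a Rearranged Core

This account rests on a few compounds, and the source may have more. Where it says the series, first, only, none or still open, it means among the compounds named here.

Three measured compounds and one unmeasured compound are closely related. Compound 1 `ClCc1ccc(Cn2cnc3c(Cl)ncnc32)cc1` and compound 2 `ClCc1ccccc1Cn1cnc2ncnc(Cl)c21` are built from the same atoms joined differently; the difference between the two cores is not broken down here. Compound 3 `ClCc1ccc(Cn2cnc3c(Cl)nc(Cl)nc32)cc1` is compound 1 with one more chlorine added: chloro in place of hydrogen on an aromatic carbon. Compound 4 `ClCc1ccccc1Cn1cnc2nc(Cl)nc(Cl)c21`, not yet measured, is compound 2 with the same addition: chloro in place of hydrogen on an aromatic carbon. The two places read identically, so this is the same change made on two cores.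

Growth inhibition was measured in a functional assay on UACC-257 cells (Homo sapiens) for cytotoxicity, read by sulforhodamine B assay, with a stated time of 48 h; on this read-out higher numbers stand for weaker inhibition of growth and lower numbers for stronger inhibition of growth. Compound 1 gives 7410 nM. Compound 2 gives 5880 nM, which lies within the usual scatter of the value for compound 1, so no order can be read from these two. Compound 3 gives 16200 nM, and the step of a 2.2-fold higher number from compound 1 to compound 3 (0.34 log units; beyond the scatter) is a modest weakening that goes beyond the scatter.

Among the compounds with values here, the only guide to compound 4 is that single measured step. The step from compound 2 is therefore expected to be a 2.2-fold higher number from compound 2 to compound 4 (0.34 log units; beyond the scatter), a weakening of similar size. The estimate for compound 4 is 13000 nM. The value expected for compound 4 is estimated to lie between 6000 nM and 28000 nM. That range is kept wide: the change has been seen only once, and the cores are not identical.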

Compound 4, concentration for 50% growth inhibition: 1990 nM
The estimate for compound 4 lay 6.5-fold (0.82 log units) above the measured number; measured number outside the range, below it.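

In this assay the added chlorine gives a 3.0-fold lower number from compound 2 to compound 4 (0.47 log units; beyond the scatter), a modest strengthening of growth inhibition, whereas the same addition on the other core gave a 2.2-fold higher number from compound 1 to compound 3 (0.34 log units; beyond the scatter), a modest weakening. Set side by side, the two steps point in opposite directions and differ by more than repeated measurements would explain, so in this series the effect of this chlorine cannot simply be carried from one core to the other: the same change on two cores in this assay, a 2.2-fold higher number (0.34 log units; beyond the scatter) from compound 1 to compound 3 and a 3.0-fold lower number (0.47 log units; beyond the scatter) from compound 2 to compound 4, 6.5-fold (0.81 log units) apart, beyond the scatter of two such steps. Within the data shown here, this shows that the surrounding core matters to the outcome of the change, but it does not show why, and with only one pair of compounds on each core it gives no rule for any other change.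

The compounds shown leave open whether the reversal belongs to chlorine alone or would also appear with another group on the aromatic carbon between two ring nitrogen atoms, such as an amine or a methoxy group. They also leave open whether the strengthening seen on the core of compound 2 would hold in cells other than the ones used here.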